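Removing the chloro from a naphthylvinyl salicylate

This account rests on a few compounds, and the source may have more. Where it says the series, first, only, none or still open, it means among the compounds named here.

Values in an ADME assay on HEK293 cells (Homo sapiens) for cytotoxicity, read by resazurin assay, with a stated time of 24 h (a lower number here means that less compound is tolerated, a higher number that more compound is tolerated), for the three measured compounds:
Compound 1, `O=C(O)c1c(O)cccc1C=Cc1ccc2ccccc2c1`: 97000 nM
Compound 2, `COc1cc(C=Cc2ccc3ccccc3c2)c(C(=O)O)c(OC)c1`: > 100000 nM, a limit of the assay and not a number
Compound 3, `COc1cc(Cl)cc(C=Cc2ccc3ccccc3c2)c1C(=O)O`: 93000 nM

Compound 3 and compound 1 give numbers whose gap lies within the scatter. Compound 2 sits at the limit of > 100000 nM in this assay, at which 1 of the 3 values shown sits.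

The next compound, compound 4, `COc1cccc(C=Cc2ccc3ccccc3c2)c1C(=O)O`, differs from compound 3 in one place: hydrogen in place of chloro on an aromatic carbon. For the measured compounds named here, only one measured step touches the same aromatic carbon, namely an at least 1.0-fold lower number from compound 2 to compound 3 (0.03 log units; that floor lies within the scatter), which puts the chloro in rather than taking it out, and it gave no movement beyond the scatter. That step and the close numbers of compounds 1 and 3 give no ground for a shift in either direction when the chloro leaves, so no step beyond the scatter is expected in this assay from compound 3 to compound 4, and the estimated step is a 1.1-fold higher number from compound 3 to compound 4 (0.03 log units; within the scatter).

Compound 4 is therefore expected to give 100000 nM in this assay, within a range from 55000 nM to 180000 nM.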

Compound 4, half-maximal cytotoxic concentration: > 100000 nM
Compound 4 ended at the assay's limit; the forecaster's own chance of this, stated with the estimate: 45%; the middle value lies on the limit itself.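

In this assay compound 4 gives > 100000 nM, a limit of the assay and not a number. Going by these compounds, the chloro leaving this aromatic carbon, para to a carboxy group, therefore yields only a floor, an at least 1.0-fold higher number from compound 3 to compound 4 (0.03 log units; that floor lies within the scatter), and methyl in place of hydrogen on the oxygen on the aromatic ring likewise yields only a floor, an at least 1.0-fold higher number from compound 1 to compound 4 (0.01 log units; that floor lies within the scatter); taking the chloro out thus shows no movement beyond the scatter, as putting it in did not, but the true size of both steps stays unknown. The step between compound 2 and compound 4 cannot be read, since both stand at the same limit: the limit of > 100000 nM in this assay, at which 2 of the 4 values shown sit.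

The compounds shown leave open whether any group on this aromatic carbon would move the number in this assay beyond the scatter, since an amine or a nitrile there is not among them. They also leave open how far compound 2 and compound 4 lie past the limit, and so whether hydrogen, methoxy and chloro at this place truly differ.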